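Swapping Methyl for Fluoro in a Shared Core

The source may hold more compounds than are shown below. What is called first, only, known or untested is meant among the compounds shown, and "the series" means these compounds.

Of the compounds shown here, three of a shared core have been tested in a functional assay on A-375 cells (Homo sapiens) for antiproliferative activity, read by MTT assay, with a stated time of 24 h, tested at 0.05 ug/mL; on this read-out higher numbers stand for a stronger effect at the one concentration tested and lower numbers for a weaker effect. Compound 1 `Cc1ccc2nc(C(=O)Nc3c(F)cc(-c4cccc(F)c4)cc3F)c(C)c(O)c2c1` gives 0.96%. Compound 2 `CCOc1ccc2nc(C(=O)Nc3c(F)cc(-c4cccc(F)c4)cc3F)c(C)c(O)c2c1`, which carries an ethoxy in place of methyl on an aromatic carbon, gives 1.02%. Compound 3 `Cc1ccc2nc(C(=O)Nc3c(F)cc(-c4cccc(F)c4)cc3F)c(C)c(C(=O)O)c2c1`, with a carboxy in place of hydroxy on an aromatic carbon, gives 0.35%. All three numbers are small, and the step of a number 0.1 percentage points higher from compound 1 to compound 2 (within the scatter) and the step of a number 0.6 percentage points lower from compound 1 to compound 3 (within the scatter) are both within the scatter. Compound 3 holds the lowest of the three numbers, yet its gaps to compound 1 and to compound 2 are within the scatter, so no order among the three can be read from them.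

Compound 4 `Cc1c(C(=O)Nc2c(F)cc(-c3cccc(F)c3)cc2F)nc2ccc(F)cc2c1C(=O)O` has not yet been measured. It differs from compound 3 in one place: fluoro in place of methyl on an aromatic carbon. Of the measured steps, none puts a fluoro where a methyl stood; the two steps that exist change other groups, and both stay within the scatter. Nothing in these steps points to a movement beyond the scatter in this assay for a change of this size. The step of a number 0.2 percentage points higher from compound 3 to compound 4 (within the scatter) is therefore expected to stay within the scatter. Compound 4 is estimated at 0.5%, with a range from -6% to 8%.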

Compound 4, a percentage reported as inhibition, at one concentration (the size of the read-out at that concentration, not a potency): 0.37%
Estimate against measurement, compound 4: 0.1 percentage points above; the measured number falls inside the stated range.
By their numbers in this assay, from the lowest: compounds 3, 4, 1 and 2 (each within the scatter of the next).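

In this assay, going by these compounds alone, fluoro in place of methyl on this aromatic carbon, which is meta to a fused ring and para to a fused ring, gives a number 0 percentage points higher from compound 3 to compound 4 (within the scatter), the first reading at this position with the carboxy group present on the shared core. Together with the earlier step of a number 0.1 percentage points higher from compound 1 to compound 2 (within the scatter), for ethoxy in place of methyl on the same carbon with hydroxy present instead of carboxy, it means that methyl, ethoxy and fluoro have now all been seen here, and neither step goes beyond the scatter, although every number is small and comes from one concentration. No measured information explains this result or says what either group does at this position.

The compounds shown leave open whether an amine, a nitrile or a longer chain such as propoxy on this carbon would move the read-out beyond the scatter. They also leave open whether fluoro here would read the same with hydroxy in place of carboxy, and whether any of these groups would separate at a higher concentration, where the numbers might be larger.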